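The compounds below may be only part of what the source reports. "The series", "measured", "known", "first", "only" and "open" are said of these compounds alone.

Going by the values given here, the three compounds measured so far share one core and differ only on the aromatic ring attached to the sulfonyl group. In a functional assay on HT-29 cells (Homo sapiens) for antiproliferative activity, read by MTT assay, with a stated time of 24 h, tested at 10 uM (on this read-out lower numbers stand for less inhibition and higher numbers for more inhibition at the one concentration tested (going by the name of the read-out)), compound 1, `O=C(NS(=O)(=O)c1ccccc1)n1ccc2cccnc21`, gives 23.6%. Compound 3, `O=C(NS(=O)(=O)c1cccc([N+](=O)[O-])c1)n1ccc2cccnc21`, gives 18.9% in this assay, and compound 2, `O=C(NS(=O)(=O)c1ccc(Cl)cc1)n1ccc2cccnc21`, gives 54.4%. Compound 2 thus stands highest of the three, with both other numbers beyond the scatter below it.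

Two steps describe what has been learned. The step of a number 30.8 percentage points higher from compound 1 to compound 2 (beyond the scatter) shows that chloro in place of hydrogen on an aromatic carbon brought a large rise. The step of a number 4.7 percentage points lower from compound 1 to compound 3 (within the scatter), nitro in place of hydrogen on an aromatic carbon, stayed within the scatter.

Compound 4, `Cc1ccc(S(=O)(=O)NC(=O)n2ccc3cccnc32)cc1`, is the next compound, differing from compound 2 by methyl in place of chloro on an aromatic carbon. Among the compounds with values here, no measured step swaps chloro for methyl; the only step that touches this position, a number 30.8 percentage points higher from compound 1 to compound 2 (beyond the scatter), says that the chloro carried the whole gain over compound 1, so removing it puts part of that gain at risk. Compound 4 is therefore expected to land between compound 1 and compound 2, at an estimated 38% with a range of 20% to 56%. The expected change is a number 16.4 percentage points lower from compound 2 to compound 4 (beyond the scatter), a fall beyond the scatter but not back to the level of compound 1.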

Compound 4, a percentage reported as inhibition, at one concentration (the size of the read-out at that concentration, not a potency): 33.4%
Compound 4: middle estimate off by 4.6 percentage points, on the high side; the measured number falls inside the stated range.
By their numbers in this assay, from the lowest: compounds 3, 1 and 4 (each within the scatter of the next, the first and the last beyond it); then compound 2.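

In this assay the change from 4-chlorophenyl to 4-methylphenyl gives a number 21 percentage points lower from compound 2 to compound 4 (beyond the scatter) and so shows that the rise seen with chloro on this aromatic carbon, para to a large group, does not carry over to every group of one heavy atom. Going by these compounds alone, the other comparison, a number 9.8 percentage points higher from compound 1 to compound 4 (within the scatter), places methyl in place of hydrogen within the scatter, which leaves chloro as the only one of these two groups at this place that stands clear of compound 1. The counts of hydrogen-bond donors and acceptors are the same for chloro and methyl, so these counts do not separate them, and nothing available here accounts for the difference in their numbers.

From the compounds shown here alone, it remains open whether bromo, fluoro, methoxy or an amine at this same place would stand with chloro or with methyl, and whether chloro would keep its rise on another carbon of the ring. Going by these compounds, each number also comes from one concentration, so how compound 2 and compound 4 compare across a range of concentrations is still unknown.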